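A Hydroxy Group Added to Compound 2

The source may hold more compounds than are shown below. What is called first, only, known or untested is meant among the compounds shown, and "the series" means these compounds.

In a functional assay on PC-3 cells (Homo sapiens) for inhibition, read by sulforhodamine B assay (a higher number here means a weaker inhibitor of growth, a lower number a stronger inhibitor of growth), compound 1 (`CN(C)c1ccc(-c2ccc(-c3ccc(-c4nc5ccccc5[nH]4)cc3)cc2)cc1`) gives 100000 nM. For the measured compounds named here, compound 2 (`Clc1cccc(-c2ccc(-c3ccc(-c4nc5ccccc5[nH]4)cc3)cc2)c1`) gives 33700 nM, the lower of the two numbers so far. Going by the values given here, the only measured step is a 3.0-fold lower number from compound 1 to compound 2 (0.47 log units; beyond the scatter), with 3-chlorophenyl in place of 4-(dimethylamino)phenyl on an aromatic carbon. Compound 3 (`Oc1cccc2[nH]c(-c3ccc(-c4ccc(-c5cccc(Cl)c5)cc4)cc3)nc12`) keeps the 3-chlorophenyl group and differs from compound 2 by hydroxy in place of hydrogen on an aromatic carbon. That carbon belongs to a six-membered aromatic ring of carbon only, part of a fused or bridged system of two rings.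

Among the compounds with values here, the measured step bears on this change only indirectly, as it concerns a different group, and no measured compound carries the hydroxy. Within the data shown here, its size, a 3.0-fold lower number from compound 1 to compound 2 (0.47 log units; beyond the scatter), is the sole guide to how far this assay moves within this small set. A modest shift towards a lower number is therefore expected, though the data do not settle its direction. The expected step is a 2.2-fold lower number from compound 2 to compound 3 (0.35 log units; beyond the scatter). For compound 3, the estimated value is 15000 nM, with an expected range of 4000 nM to 50000 nM.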

Compound 3, concentration for 50% growth inhibition: 2560 nM
Compound 3: middle estimate off by 5.9-fold (0.77 log units), on the high side; the whole stated range lies above it.
By their numbers in this assay, from the lowest: compound 3; then compound 2; then compound 1.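

In this assay, hydroxy in place of hydrogen gives a 13-fold lower number from compound 2 to compound 3 (1.12 log units; beyond the scatter), a large step from a group of 1 heavy atom on the six-membered aromatic ring of carbon only. This step is larger than the only earlier one, a 3.0-fold lower number from compound 1 to compound 2 (0.47 log units; beyond the scatter), which came from 3-chlorophenyl in place of 4-(dimethylamino)phenyl, so this position on the shared core, ortho to a fused ring and meta to a fused ring, matters at least as much in this small set as the change at the far aromatic group. Nothing given here explains why the hydroxy has so large an effect on the number.

The compounds shown leave open whether the step belongs to the hydroxy itself, as a methoxy group or an amine on the same carbon could give a similar number or a very different one. They also leave open whether the hydroxy would bring a step of this size alongside the 4-(dimethylamino)phenyl group of compound 1, or on another carbon of the same ring.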